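The source may hold more compounds than are shown below. What is called first, only, known or untested is meant among the compounds shown, and "the series" means these compounds.

Measured compounds:
- compound 1, `O=C(CN1CCC(c2cccc[n+]2[O-])CC1)Nc1ccc(F)cc1F`, 103 nM in a functional assay on HEK293 cells for agonist activity at D(4) dopamine receptor (Homo sapiens), read by FLIPR; a lower number here means that less compound is needed, a higher number that more compound is needed for the effect
- compound 2, `Cc1ccc(Cl)c(NC(=O)CN2CCC(c3cccc[n+]3[O-])CC2)c1Cl`, 346 nM
- compound 3, `c1ccc(C2CCN(Cc3nc4ccccc4[nH]3)CC2)nc1`, 12 nM

Among these three numbers compound 1 stands second highest: compound 2 sits higher by a margin beyond the usual scatter, and compound 3 sits lower by a margin that is also beyond the scatter. Compound 4, `Cc1cc(Br)ccc1NC(=O)CN1CCC(c2cccc[n+]2[O-])CC1`, has not yet been measured. It differs from compound 1 in one place: 4-bromo-2-methylphenyl in place of 2,4-difluorophenyl on an amide-type nitrogen.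

Among the compounds with values here, no step between two measured compounds isolates this change. Compound 2, which also carries a halogen-and-methyl-bearing ring on the amide-type nitrogen, gives 346 nM, a higher number than compound 1, so a modest rise is expected here, though possibly within the scatter. The step of a 1.9-fold higher number from compound 1 to compound 4 (0.29 log units; within the scatter) is the expected size. Compound 4 is estimated at 200 nM, with a range from 70 nM to 600 nM.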

Compound 4, half-maximal effective concentration: 66 nM
Estimate against measurement, compound 4: 3.0-fold (0.48 log units) above; measured number below the stated range.
By their numbers in this assay, from the lowest: compound 3; then compounds 4 and 1 (each within the scatter of the next); then compound 2.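

For this assay the swap of 2,4-difluorophenyl for 4-bromo-2-methylphenyl on the amide-type nitrogen is a 1.6-fold lower number from compound 1 to compound 4 (0.19 log units; within the scatter) and so cannot be told apart from repeat-measurement noise. This position therefore accepts two differently substituted rings of equal heavy-atom count with no readable change in the number. No measurement shown explains this result.

Going by these compounds, whether the bromine and the methyl would each give the same result alone remains open. So does the effect of a ring carrying an amine or a carboxylic acid, or of a longer chain on this nitrogen.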